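Nitro in place of amino: working notes on compound 4

A few compounds are considered here, and "the series" means these few. Any claim that something is new, unique, unknown or untested is made for them only; others in the source may bear on it.

Three compounds share one core and differ in a single aromatic substituent. In a functional assay on the whole organism with Mus musculus as the target (on this read-out higher numbers stand for an effect only at larger amounts of compound and lower numbers for an effect already at smaller amounts), compound 1 (`COc1cc2c(cc1OC)C(c1ccc(Br)cc1)=NN(C)C(=S)C2`) carries bromo and gives 60.4 umol/kg as its reading. Compound 2 (`COc1cc2c(cc1OC)C(c1ccccc1)=NN(C)C(=S)C2`) carries hydrogen and gives 24.7 umol/kg on the same read-out. Compound 3 (`COc1cc2c(cc1OC)C(c1ccc(N)cc1)=NN(C)C(=S)C2`) carries amino and gives 20.3 umol/kg, which places it level with compound 2 and well clear of compound 1. The step of a 1.2-fold lower number from compound 2 to compound 3 (0.09 log units; within the scatter) separates nothing.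

Compound 4 (`COc1cc2c(cc1OC)C(c1ccc([N+](=O)[O-])cc1)=NN(C)C(=S)C2`) is the next case, with nitro in place of amino on an aromatic carbon, para to a large group: nitro in place of amino on an aromatic carbon. Going by the values given here, no nitro compound has been measured, so the guide is indirect. Among the compounds with values here, only bromo has moved the number so far, as seen in a 2.4-fold lower number from compound 1 to compound 2 (0.39 log units; beyond the scatter) and in a 3.0-fold lower number from compound 1 to compound 3 (0.47 log units; beyond the scatter), both modest. A step of about that size toward a higher number is expected, with no-change still plausible given the step between hydrogen and amino. The estimated change is a 1.9-fold higher number from compound 3 to compound 4 (0.27 log units; within the scatter) on this basis. For compound 4 the expected value in this assay is 38 umol/kg, with an estimated range from 16 umol/kg to 85 umol/kg as the working figures.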

Compound 4, dose for half-maximal effect: 81.5 umol/kg
Estimate against measurement, compound 4: 2.1-fold (0.33 log units) below; the measured number falls inside the stated range.
By their numbers in this assay, from the lowest: compounds 3 and 2 (each within the scatter of the next); then compounds 1 and 4 (each within the scatter of the next).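

Until now, the aromatic position para to a large group had only shown bromo apart from hydrogen and amino, and swapping hydrogen for amino changed nothing that could be read. Nitro now gives a second group that separates from that pair in this assay: the readings show a 4.0-fold higher number from compound 3 to compound 4 (0.60 log units; beyond the scatter) and a 3.3-fold higher number from compound 2 to compound 4 (0.52 log units; beyond the scatter), both beyond the scatter, while a 1.3-fold higher number from compound 1 to compound 4 (0.13 log units; within the scatter) leaves nitro and bromo level with each other, so the four compounds fall into two pairs, hydrogen with amino and bromo with nitro. The readings come with no supporting measurement of any kind, so the split between the pairs stands as an observation on these four compounds alone.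

Still open, from the compounds shown here alone, is where other groups at this same position would fall, for instance a nitrile, a carboxylic acid or a dimethylamino group, and whether any of them would read lower than the hydrogen and amino pair or higher than the bromo and nitro pair. Also open, going by these compounds, is whether the same two pairs would appear with these groups elsewhere on this aromatic ring, or with a change to the shared core.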